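The source may report more compounds than this note shows. Statements on the series, on what has been measured and on what is new or still open speak of the compounds shown alone.

Measured compounds: compound 1 `COc1ccc(/C=C/C(=O)c2cc(-c3ccc(OC)c(OC)c3)n3nc(-c4ccccc4)cc3n2)cc1`, 14900 nM; compound 2 `COc1ccc(/C=C/C(=O)c2cc(-c3cc(OC)c(OC)c(OC)c3)n3nc(-c4ccccc4)cc3n2)cc1OC`, 15300 nM; compound 3 `COc1ccc(/C=C/C(=O)c2cc(-c3cc(OC)c(OC)c(OC)c3)n3nc(-c4ccccc4)cc3n2)cc1`, 16900 nM.

In a functional assay on DU-145 cells (Homo sapiens) for antiproliferative activity, read by MTT assay, with a stated time of 24 h (on this read-out lower numbers stand for stronger inhibition and higher numbers for weaker inhibition), compound 1 gives the lowest of the three numbers, though its nearest neighbour compound 2 and its furthest compound 3 both stay within the scatter of it. The steps of a 1.1-fold higher number from compound 1 to compound 3 (0.05 log units; within the scatter) and a 1.1-fold higher number from compound 2 to compound 3 (0.04 log units; within the scatter) change only methoxy groups and both fall within the scatter.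

Compound 4 `COc1ccc(-c2cc(/C=C/C(=O)c3ccccc3)nc3cc(-c4ccccc4)nn23)cc1OC` differs from compound 1 by 2-benzoylethenyl in place of (2-(4-methoxyphenyl)ethenyl)carbonyl on an aromatic carbon. Within the data shown here, no measured step touches this part of the molecule, so nothing here bears on it directly; the only guidance is that the three measured values sit close together. The expected step of a 1.1-fold higher number from compound 1 to compound 4 (0.03 log units; within the scatter) is therefore small, and compound 4 is estimated at 16000 nM, between 5000 nM and 50000 nM.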

Compound 4, half-maximal inhibitory concentration: 10000 nM
Compound 4: the middle estimate sits 1.6-fold (0.20 log units) above what was measured; the measured number falls inside the stated range.
By their numbers in this assay, from the lowest: compounds 4, 1, 2 and 3 (each within the scatter of the next).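

Among these compounds, at this position, the first change to the side chain itself gives a 1.5-fold lower number from compound 1 to compound 4 (0.17 log units; within the scatter) in this assay, so 2-benzoylethenyl can replace (2-(4-methoxyphenyl)ethenyl)carbonyl with the number still within the scatter. The swap moves the carbonyl and removes the methoxy group on the terminal aromatic ring together, and this pair cannot separate the two. Nothing available explains the size of this step.

Still open, from the compounds shown here alone, is whether any group here moves the number beyond the scatter. An amine or a carboxylic acid in this place would test that.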